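Replacing chloro with methoxy on a shared core

The source may report more compounds than this note shows. Statements on the series, on what has been measured and on what is new or still open speak of the compounds shown alone.

Of the compounds shown here, three with a shared core have been tested in a functional assay on MDA-MB-231 cells (Homo sapiens) for cytotoxicity, read by MTT assay, with a stated time of 72 h (on this read-out higher numbers stand for weaker inhibition and lower numbers for stronger inhibition), so far. Compound 1 `Brc1cccc2cc3c(nc12)-c1nc2ccccc2n1C3` gives 11300 nM as its half-maximal inhibitory concentration. Compound 2 `Clc1cccc2cc3c(nc12)-c1nc2ccccc2n1C3` gives 69000 nM and so holds the higher of the two exact numbers, which marks it as the weaker of that pair. Compound 3 `Cc1ccc2nc3c(cc2c1)Cn1c-3nc2ccccc21` is reported only as a limit of > 100000 nM rather than as an exact number.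

The next step leads to compound 4 `COc1cccc2cc3c(nc12)-c1nc2ccccc2n1C3`, which has methoxy in place of chloro on an aromatic carbon with the rest of compound 2 unchanged. No methoxy swap has been measured in this series. The closest guide is the exchange of bromo for chloro, which gave a 6.1-fold higher number from compound 1 to compound 2 (0.79 log units; beyond the scatter) and shows that one group at this place can modestly move the number. That step involves different groups, so it suggests a possible size but not a direction. The expected outcome is therefore little real change, with an estimated 1.2-fold higher number from compound 2 to compound 4 (0.06 log units; within the scatter) in this assay as the best guess. Compound 4 is expected at about 80000 nM on this read-out, with an estimated range from 25000 nM to 200000 nM for the measurement.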

Compound 4, half-maximal inhibitory concentration: > 100000 nM
Compound 4: a limit, no number; the forecaster's own chance of this, stated with the estimate: 45%; middle value at least 1.2-fold (0.09 log units) from the limit.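

In this assay compound 4 is reported only as a limit, > 100000 nM, and not as an exact number. Methoxy in place of chloro therefore gives only a floor, an at least 1.4-fold higher number from compound 2 to compound 4 (0.16 log units; that floor lies within the scatter), so this swap may have changed little or a great deal, whereas the comparison with the bromo compound is clearer, with an at least 8.8-fold higher number from compound 1 to compound 4 (0.94 log units; beyond the scatter). At this place on the aromatic carbon, compound 1, which carries bromo, now gives a lower number than both compound 2 and compound 4, and a second compound in the series sits at the same limit: the limit of > 100000 nM in this assay, at which 2 of the 4 values shown sit.

As far as these compounds go, without an exact number for compound 4, how far methoxy and chloro truly differ at this place stays open, and so does how far compound 4 lies from compound 1. From the compounds shown here alone, it is also open whether the lower number of compound 1 is particular to bromo, or whether another group on the same aromatic carbon, such as iodo, an amine or a carboxylic acid, would give a number as low or lower.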